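The source may hold more compounds than are shown below. What is called first, only, known or untested is meant among the compounds shown, and "the series" means these compounds.

Measured compounds:
- compound 1, `CCCCCCCCCCCC(=O)C(C)(C)C(=O)N(C)c1c(OC)cc(OC)cc1OC`: in a functional assay on microsomes from intestine for inhibition of acyl-CoA:cholesterol acyltransferase (Oryctolagus cuniculus) (a lower number here means a stronger inhibitor, a higher number a weaker inhibitor), compound 1 reads > 1000 nM, a limit of the assay and not a number.
- compound 2, `CCCCCCCCCCCC(=O)C(C)(C)C(=O)N(C)c1c(C(C)C)cccc1C(C)C`: in this assay compound 2 gives 1000 nM.
- compound 3, `CC(C)c1cccc(C(C)C)c1NC(=O)CC(=O)CCCCCCCCCCO`: in this assay compound 3 gives 230 nM.

Compound 3 holds the lowest of the two numbers available; compound 2, its nearest neighbour, sits higher by a gap beyond the usual scatter. Compound 1 offers no number, only the limit (the limit of > 1000 nM in this assay, at which 1 of the 3 values shown sits), so it cannot be ranked against the other two.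

Compound 4, `CCCCCCCCCCCCCC(=O)CC(=O)Nc1c(C(C)C)cccc1C(C)C`, differs from compound 3 by a single change: propyl in place of hydroxy on a saturated chain carbon, ten or more bonds along the chain from a carbonyl carbon. Going by the values given here, no measured pair in this set carries that change alone, so no step size is anchored by data. The expectation is a modest lowering of the number in this assay, estimated as a 2.3-fold lower number from compound 3 to compound 4 (0.36 log units; beyond the scatter), with a result inside the scatter also plausible. For compound 4 the expected value in this assay is 100 nM, in a range from 30 nM to 400 nM.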

Compound 4, half-maximal inhibitory concentration: 6 nM
Compound 4: middle estimate off by 17-fold (1.22 log units), on the high side, outside the stated range (below it).
By their numbers in this assay, from the lowest: compound 4; then compound 3; then compound 2.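

In this assay, the end of the chain turns out to be a strong lever on the number: a 38-fold lower number from compound 3 to compound 4 (1.58 log units; beyond the scatter), for propyl in place of hydroxy on a saturated chain carbon, ten or more bonds along the chain from a carbonyl carbon. Going by these compounds alone, this is the first step anchored by two compounds that differ in one place, and it shows that this far position is not a neutral spot on the chain. Within the data shown here, nothing measured so far bears on what lies behind a step of this size.

Among these compounds, the single pair does not separate the loss of the hydroxy from the gain of the added carbons. A terminal amine, a carboxylic acid or a longer chain at this position would show which of the two carries the step, and whether the trend continues.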